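A few compounds are considered here, and "the series" means these few. Any claim that something is new, unique, unknown or untested is made for them only; others in the source may bear on it.

Measured in a physicochemical assay for solubility, read by LC-MS, with a stated time of 16 h, at pH 7; a higher number here means a more soluble compound, a lower number a less soluble compound:
- compound 1 `CCCC[S+]([O-])c1sc2nc(-c3nccs3)cc(-c3nccs3)c2c1N`: 0.3 ug/mL
- compound 2 `CCCC[S+]([O-])c1sc2nc(-c3nccs3)cc(-c3ccc(COC(=O)CN(C)C)cc3)c2c1N`: 6 ug/mL
- compound 3 `CCCC[S+]([O-])c1sc2nc(-c3nccs3)cc(-c3ccc(CO)cc3)c2c1N`: 12.5 ug/mL

Compound 3 holds the highest number of the three. Compound 4 `CCCC[S+]([O-])c1sc2nc(-c3nccs3)cc(-c3ccc(CNC(=O)NCC)cc3)c2c1N` differs from it as follows: (ethylcarbamoyl)amino in place of hydroxy on a saturated chain carbon bound to an aromatic carbon. That is, (ethylcarbamoyl)amino in place of hydroxy on a saturated chain carbon bound to an aromatic carbon. The closest evidence is a 2.1-fold higher number from compound 2 to compound 3 (0.32 log units; beyond the scatter), a modest step that also changes what sits on the hydroxy oxygen. The larger 42-fold higher number from compound 1 to compound 3 (1.62 log units; beyond the scatter) swaps a whole ring substituent and bears only loosely. For the measured compounds named here, no measured step puts a nitrogen group in place of hydroxy. In this assay the expected move is downward and modest to moderate, an estimated 3.1-fold lower number from compound 3 to compound 4 (0.49 log units; beyond the scatter). Compound 4 is expected at 4 ug/mL, within 1 ug/mL to 12 ug/mL.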

Compound 4, solubility: 8.17 ug/mL
Beside the measured number, compound 4's estimate is 2.0-fold (0.31 log units) below it, within the range that was stated.
By their numbers in this assay, from the lowest: compound 1; then compounds 2, 4 and 3 (each within the scatter of the next, the first and the last beyond it).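

In this assay, the saturated chain carbon bound to an aromatic carbon carries (ethylcarbamoyl)amino in place of hydroxy with a 1.5-fold lower number from compound 3 to compound 4 (0.18 log units; within the scatter), so a group of 6 heavy atoms replaces one of 1 without a step beyond the scatter. The comparison with (((dimethylamino)methyl)carbonyl)oxy at the same place also stays within the scatter, with a 1.4-fold higher number from compound 2 to compound 4 (0.13 log units; within the scatter). No measurement on hand explains either step.

Still open, as far as these compounds go, is how a primary amine or a carboxylic acid at this place would read in this assay. From the compounds shown here alone, a longer chain in place of the ethyl of (ethylcarbamoyl)amino is equally open.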